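A few compounds are considered here, and "the series" means these few. Any claim that something is new, unique, unknown or untested is made for them only; others in the source may bear on it.

Working notes on the series in a functional assay on the whole organism (strain STD-dd) with Mus musculus as the target, in the maximal electroshock model, with a stated time of 2 h; on this read-out higher numbers stand for an effect only at larger amounts of compound and lower numbers for an effect already at smaller amounts.

Of the compounds shown here, three carry numbers so far. Compound 1 `CCNS(=O)(=O)Cc1noc2ccccc12` gives 39 mg/kg in this assay. Compound 2 `NS(=O)(=O)Cc1noc2ccc(Br)cc12` gives 14 mg/kg. Compound 3 `CNS(=O)(=O)Cc1noc2ccc(Br)cc12` gives 15 mg/kg. On these numbers compound 3 stands second highest of the three; its nearest neighbour is compound 2, and the step of a 1.1-fold higher number from compound 2 to compound 3 (0.03 log units; within the scatter) lies within the scatter, so the two are not to be ordered. Its furthest neighbour is compound 1, whose number is the higher of the pair and beyond the scatter from that of compound 3.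

The next compound, compound 4 `CCNS(=O)(=O)Cc1noc2ccc(Br)cc12`, is not yet measured. Its change from compound 3 is methyl in place of hydrogen on a saturated chain carbon bound to a sulfonamide nitrogen. Going by the values given here, the only measured step that bears on this position is a 1.1-fold higher number from compound 2 to compound 3 (0.03 log units; within the scatter), which concerns the sulfonamide nitrogen itself and was within the scatter; no measured step covers methyl to ethyl on that chain. On that basis no step beyond the scatter is expected in this assay, with some allowance for a somewhat higher number. Compound 4 is therefore estimated at 18 mg/kg, within a range of 9 mg/kg to 36 mg/kg, which means an expected step of a 1.2-fold higher number from compound 3 to compound 4 (0.08 log units; within the scatter).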

Compound 4, dose for half-maximal effect: 18 mg/kg
Estimate against measurement, compound 4: no gap at the digits printed; low and high end bracket the measured number.
By their numbers in this assay, from the lowest: compounds 2, 3 and 4 (each within the scatter of the next); then compound 1.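

In this assay, methyl to ethyl on the sulfonamide nitrogen gives a 1.2-fold higher number from compound 3 to compound 4 (0.08 log units; within the scatter) and ethyl in place of hydrogen on that nitrogen gives a 1.3-fold higher number from compound 2 to compound 4 (0.11 log units; within the scatter) so, with bromo on the core, hydrogen, methyl and ethyl on the nitrogen cannot be ordered. Compound 4 also gives the first reading of the bromo group at a single place, since bromo in place of hydrogen on an aromatic carbon gives a 2.2-fold lower number from compound 1 to compound 4 (0.34 log units; beyond the scatter) and this modest step is the only single-place step shown that lies beyond the scatter. No available data speak to what lies behind either result.

Open, from the compounds shown here alone, is whether a longer chain such as propyl or butyl, a cyclopropyl ring or a second substituent on the sulfonamide nitrogen would also stay within the scatter, since the readings so far stop at ethyl. Also open, going by these compounds, is whether the bromo step holds with hydrogen or methyl on the nitrogen, and whether chloro, fluoro or methoxy on that aromatic carbon would give a step of similar size.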